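The source may hold more compounds than are shown below. What is called first, only, known or untested is meant among the compounds shown, and "the series" means these compounds.

Measured so far:
Compound 1 `Cc1ccc2oc(SCC(=O)Nc3ccc(-c4nc(-c5ccccc5)c(-c5ccccc5)n4C)cc3)nc2c1`: 1.9%
Compound 2 `Cn1cnnc1SCC(=O)Nc1ccc(-c2nc(-c3ccccc3)c(-c3ccccc3)n2C)cc1`: 42.8%

Both compounds share a core and differ only in the group attached to the sulfur. In a functional assay on MCF7 cells (Homo sapiens) for cytotoxicity, read by MTT assay, with a stated time of 24 h, tested at 1.6 ug/mL (on this read-out higher numbers stand for a stronger effect at the one concentration tested and lower numbers for a weaker effect), compound 1 gives 1.9%, and compound 2 gives 42.8%. Going by the values given here, that is the step of a number 40.9 percentage points higher from compound 1 to compound 2 (beyond the scatter), so on these two numbers compound 2 stands highest, with compound 1 as its only and much lower neighbour.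

Compound 3 `CN(C)/C=C/N1CCN(CC(=O)Nc2ccc(-c3nc(-c4ccccc4)c(-c4ccccc4)n3C)cc2)CC1` takes a different route at the same part of the molecule: 4-(2-(dimethylamino)ethenyl)piperazin-1-yl in place of (4-methyl-4H-1,2,4-triazol-3-yl)sulfanyl on a saturated chain carbon bound to a carbonyl carbon. Among the compounds with values here, the one measured step, from compound 1 to compound 2, shows that swapping the group at this position can move the read-out by a large amount, but it concerns two sulfur-linked aromatic groups, whereas here the whole sulfur-linked group is removed and a non-aromatic ring takes its place. Within the data shown here, there is therefore no direct precedent for the direction.

Given that, compound 3 is expected to come out somewhat lower than compound 2, with a wide range, at 28% (between 4% and 60%); the expected step is a number 14.8 percentage points lower from compound 2 to compound 3 (beyond the scatter).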

Compound 3, a percentage reported as activity, at one concentration (the size of the read-out at that concentration, not a potency): 1.9%
Beside the measured number, compound 3's estimate is 26.1 percentage points above it; measured number below the stated range.
By their numbers in this assay, from the lowest: compounds 1 and 3 (each within the scatter of the next); then compound 2.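

Replacing the sulfur-linked triazole of compound 2 with the piperazine of compound 3 costs a large part of the read-out in this assay (a number 40.9 percentage points lower from compound 2 to compound 3 (beyond the scatter)), so a group without sulfur and without an aromatic ring does not keep the effect seen with compound 2. The same piperazine set against the sulfur-linked benzoxazole of compound 1 gives a result within the scatter (no change at the digits printed from compound 1 to compound 3 (within the scatter)), which means that two very different groups on this saturated chain carbon end up at the same low level, and among these three compounds only the (4-methyl-4H-1,2,4-triazol-3-yl)sulfanyl group stands clear of that level. Nothing available here gives a measured explanation for this difference between the groups.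

The step to compound 3 changes the sulfur link and the ring at the same time, so the compounds shown cannot say which of the two matters, and a 4-methyl-4H-1,2,4-triazol-3-yl group joined through an oxygen, or a plain morpholine, would help to separate them. All of these numbers also come from a single concentration, which leaves open how the compounds compare in potency.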